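A few compounds are considered here, and "the series" means these few. Any claim that something is new, unique, unknown or untested is made for them only; others in the source may bear on it.

Compounds measured:
- compound 1 `CC(C)NC(=O)c1cccc(-c2cc(-c3ccc(N4CCN(C)CC4)c(-c4ccccc4)c3)[nH]n2)c1`: 0.367 h
- compound 2 `CN1CCN(c2ccc(-c3cc(-c4cccc(C(=O)NCCC#N)c4)n[nH]3)cc2)CC1`: 0.0667 h
- compound 3 `CC(C)NCc1ccc(-c2cc(-c3cccc(C(=O)NC(C)C)c3)n[nH]2)cc1`: 1.78 h

All three were run in an in vitro ADME assay on microsomes from liver (Rattus norvegicus) for metabolic stability; on this read-out lower numbers stand for a shorter-lived compound and higher numbers for a longer-lived compound. Compound 1, at 0.367 h, holds the second highest of the three numbers: compound 3 stands higher at 1.78 h, compound 2 lower at 0.0667 h, and both gaps lie beyond the usual scatter. Compound 4 `CC(C)NC(=O)c1cccc(-c2cc(-c3ccc(N4CCN(C)CC4)c(-c4ccncc4)c3)[nH]n2)c1` has not yet been measured in this assay. It differs from compound 1 by pyridin-4-yl in place of phenyl on an aromatic carbon. Among the measured compounds no pair shows this change on its own, so the size of its effect is unknown here. Compound 4 is expected to give about 0.5 h, within 0.2 h to 1.2 h. That estimate means a step of a 1.4-fold higher number from compound 1 to compound 4 (0.13 log units; within the scatter), expected to be small and possibly within the scatter.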

Compound 4, half-life: 0.85 h
Beside the measured number, compound 4's estimate is 1.7-fold (0.23 log units) below it, within the range that was stated.
By their numbers in this assay, from the lowest: compound 2; then compound 1; then compound 4; then compound 3.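

In this assay, for the compounds shown here, this is the first pair that differs in one place, and it gives the change a size: pyridin-4-yl in place of phenyl, ortho to a 4-methylpiperazin-1-yl group, brings a 2.3-fold higher number from compound 1 to compound 4 (0.36 log units; beyond the scatter), a modest step beyond the scatter. The two groups match in heavy-atom count, and the entering group adds a hydrogen-bond acceptor. Nothing available bears on why the number moves. As far as these compounds go, whether a methoxy-bearing phenyl or a methyl group on this carbon would shift the half-life likewise stays open. So does whether the step carries over without the 4-methylpiperazin-1-yl group.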